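A few compounds are considered here, and "the series" means these few. Any claim that something is new, unique, unknown or untested is made for them only; others in the source may bear on it.

Of the compounds shown here, two have so far been measured in a physicochemical assay for solubility, in phosphate buffer, with a stated time of 18 h; a lower number here means a less soluble compound, a higher number a more soluble compound. Compound 1 `Cc1ncc2c(N)c(C#N)c(N)nc2n1` gives 783000 nM, and compound 2 `N#Cc1c(N)nc2nc(C3CCCC3)ncc2c1N` gives 89000 nM, which is the lower of the two numbers. Compound 2 therefore stands at the bottom of this short series. The next compound to be measured is compound 3 `CC(C)Cc1ncc2c(N)c(C#N)c(N)nc2n1`. It carries isobutyl in place of cyclopentyl on an aromatic carbon, between two ring nitrogen atoms, and the change is counted as isobutyl in place of cyclopentyl on an aromatic carbon. Among the measured compounds shown here, no measured step exchanges a ring for an open chain, so only one step bears on this change, at the same place on the shared core. That step, with cyclopentyl in place of methyl, is an 8.8-fold lower number from compound 1 to compound 2 (0.94 log units; beyond the scatter) and is modest in size. Compound 3 is expected to fall within the span set by compound 1 at 783000 nM and compound 2 at 89000 nM, towards the lower end of that span. The estimated step is small and upward, a 1.8-fold higher number from compound 2 to compound 3 (0.25 log units; within the scatter). The expected value for compound 3 is 160000 nM, with an estimated range from 70000 nM to 450000 nM.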

Compound 3, solubility: 268000 nM
Compound 3: the middle estimate sits 1.7-fold (0.22 log units) below what was measured, within the range that was stated.
By their numbers in this assay, from the lowest: compound 2; then compound 3; then compound 1.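

In this assay, the position on an aromatic carbon between two ring nitrogen atoms proves sensitive to a change from one carbon-only group to another: opening the cyclopentyl ring to isobutyl gives a 3.0-fold higher number from compound 2 to compound 3 (0.48 log units; beyond the scatter) and so separates the two groups. Read as isopropyl in place of hydrogen on the saturated chain carbon bound to the aromatic carbon, the same compound also stands apart from the methyl compound, with a 2.9-fold lower number from compound 1 to compound 3 (0.47 log units; beyond the scatter) and thus a placing between the other two compounds. The three compounds therefore give three separate values at this one position, yet nothing given here accounts for either step.

The compounds shown leave open whether the ring itself or the particular group matters at this position, a question that a straight butyl chain, a cyclopropyl or a cyclohexyl group could help to settle. They also leave open how an amine or an ether at the same position would read, and how changes to the amino groups or the nitrile on the shared core would compare.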